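The source may hold more compounds than are shown below. What is called first, only, known or untested is meant among the compounds shown, and "the series" means these compounds.

Measured compounds in a functional assay on M14 cells (Homo sapiens) for cytotoxicity, read by sulforhodamine B assay, with a stated time of 48 h; on this read-out lower numbers stand for stronger inhibition of growth and higher numbers for weaker inhibition of growth:
compound 1 `ClCc1ccccc1Cn1cnc2c(Cl)nc(Cl)nc21`, 2810 nM
compound 2 `ClCc1cccc(Cn2cnc3c(Cl)nc(Cl)nc32)c1`, 3380 nM
compound 3 `Nc1nc(Cl)c2ncn(Cc3ccccc3CCl)c2n1`, 39800 nM

Compound 1 and compound 2 share the same atoms, joined differently; the difference between their two cores is not broken down here. Their values in this assay lie within the scatter of one another, so no order is read from them.

Compound 3 carries one change relative to compound 1: amino in place of chloro on an aromatic carbon. This change gave a 14-fold higher number from compound 1 to compound 3 (1.15 log units; beyond the scatter).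

Compound 4 `Nc1nc(Cl)c2ncn(Cc3cccc(CCl)c3)c2n1` is not yet measured. It stands to compound 2 as compound 3 stands to compound 1: amino in place of chloro on an aromatic carbon. The place line is the same word for word in both cases, so this is the same change made on the core of compound 2.

Within the data shown here, for compound 4 the expectation rests on the single earlier instance of this change, a 14-fold higher number from compound 1 to compound 3 (1.15 log units; beyond the scatter), applied to the value of compound 2; a step of a 13-fold higher number from compound 2 to compound 4 (1.12 log units; beyond the scatter) is expected. Among the measured compounds shown here, the estimate for compound 4 in this assay is 45000 nM, with a range from 18000 nM to 110000 nM, the width reflecting that only one prior instance supports it.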

Compound 4, concentration for total growth inhibition: 11700 nM
For compound 4 the middle estimate is 3.8-fold (0.59 log units) above the measured one, outside the stated range (below it).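

Amino in place of chloro on an aromatic carbon moves the number the same way on a second core in this assay, giving a 3.5-fold higher number from compound 2 to compound 4 (0.54 log units; beyond the scatter), so the direction of the step carries across the two cores shown. Its size does not carry across, and the two instances differ by more than the scatter: the same change on two cores in this assay, a 14-fold higher number (1.15 log units; beyond the scatter) from compound 1 to compound 3 and a 3.5-fold higher number (0.54 log units; beyond the scatter) from compound 2 to compound 4, 4.1-fold (0.61 log units) apart, beyond the scatter of two such steps. Two instances do not show what sets the size of the step on a given core, and they give no ground for taking the size measured on one core as the size on the other.

The aromatic carbon that carries the change holds only chloro or amino in the compounds shown, so a methylamino, a hydroxyl or a methoxy group there remains open. Also open, as far as these compounds go, is whether the direction of the step holds on a core in which a hydroxymethyl group or a longer chain ending in chloro takes the place of the chloromethyl group.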